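The source may hold more compounds than are shown below. What is called first, only, known or untested is meant among the compounds shown, and "the series" means these compounds.

In a functional assay on CNE cells (Homo sapiens) for cytotoxicity, read by MTT assay, with a stated time of 72 h (a lower number here means a stronger inhibitor, a higher number a weaker inhibitor), two compounds of this series have been measured. Compound 1 `COc1ccc(/C=C/C(=O)OCC(=O)Nc2ccc(Cl)cc2)cc1OC` gives only a limit of the assay, reported as > 200000 nM. Compound 1 thus sits at the limit of this assay (the limit of > 200000 nM in this assay, at which 1 of the 2 values shown sits). Among the compounds with values here, compound 2 `O=C(COC(=O)/C=C/c1ccc(O)c(O)c1)Nc1ccc(Cl)cc1` gives the one actual number in the set, 89600 nM, and so is the only measured compound of the pair with a value inside the range of this assay. Within the data shown here, no step between these two is counted here, and nothing beyond their two values is taken from the comparison.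

The next compound, compound 3 `O=C(COC(=O)/C=C/c1ccc(O)c(O)c1)NN1CCOCC1`, differs from compound 2 in one place (morpholin-4-yl in place of 4-chlorophenyl on an amide-type nitrogen). Among the measured compounds shown here, no measured pair shows what this kind of change does. For the measured compounds named here, the expectation therefore rests on compound 2 alone and on the fact that the series so far sits at or beyond the weak end of this assay. The step from compound 2 to compound 3 is expected to be a 1.7-fold higher number from compound 2 to compound 3 (0.22 log units; within the scatter), towards weaker inhibition, with a fair chance that the change is no larger than the scatter. Compound 3 is therefore estimated at 150000 nM in this assay, within a range from 50000 nM to 300000 nM.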

Compound 3, half-maximal inhibitory concentration: > 200000 nM
Compound 3 was reported as a limit; the forecaster's own chance of this, stated with the estimate: 40%; middle value at least 1.3-fold (0.12 log units) away from the limit.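

Within the data shown here, this is the first step that can be read: morpholin-4-yl in place of 4-chlorophenyl on an amide-type nitrogen gives an at least 2.2-fold higher number from compound 2 to compound 3 (0.34 log units; beyond the scatter), towards weaker inhibition in this assay. On these data alone, compound 3 gives > 200000 nM, which is a limit of the assay and not a number, so the step is a lower bound and its full size stays unknown. On the core shared by compound 2 and compound 3, only the 4-chlorophenyl compound keeps a value inside the range of the assay, and the set now gathers at its weak end: the limit of > 200000 nM in this assay, at which 2 of the 3 values shown sit.

The compounds shown cannot separate the parts of this change, since the aromatic ring of carbon only gives way to a non-aromatic ring with hetero atoms and hydrogen-bond acceptors in a single step. As far as these compounds go, whether a piperidin-1-yl group, which keeps a non-aromatic ring with one hetero atom fewer, or an unsubstituted phenyl group on this nitrogen would give a value inside the range stays open.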